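A few compounds are considered here, and "the series" means these few. Any claim that something is new, unique, unknown or untested is made for them only; others in the source may bear on it.

Three compounds have been measured in a functional assay on MV4-11 cells (Homo sapiens) for antiproliferative activity, read by CCK-8 assay, with a stated time of 72 h; a lower number here means a stronger inhibitor, a higher number a weaker inhibitor:

Compound 1 `Cn1cc(-c2ccccc2F)c2cc(C(=O)NCc3ccc(C(=O)Nc4ccccc4N)cc3)[nH]c2c1=O`: 230 nM
Compound 2 `CC(C)Oc1ccc(C(C)(C)O)cc1-c1cn(C)c(=O)c2[nH]c(C(=O)NCc3ccc(C(=O)Nc4ccccc4N)cc3)cc12`: 40 nM
Compound 3 `Cn1cc(-c2ccccc2Oc2ccccc2)c2cc(C(=O)NCc3ccc(C(=O)NO)cc3)[nH]c2c1=O`: 570 nM

Compound 2, at 40 nM, has the lowest number of the three. The nearest is compound 1 at 230 nM, and the furthest is compound 3 at 570 nM. Both gaps lie beyond the usual scatter.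

The next compound to be tested in this assay is compound 4 `COc1ccc(C(C)(C)O)cc1-c1cn(C)c(=O)c2[nH]c(C(=O)NCc3ccc(C(=O)Nc4ccccc4N)cc3)cc12`. It differs from compound 2 in one place: methyl in place of isopropyl on an oxygen on an aromatic ring. This is methyl in place of isopropyl on an oxygen on an aromatic ring, or isopropoxy to methoxy. Among the measured compounds shown here, no measured pair shows this change on its own, so the expectation rests on compound 2 at 40 nM and on the change itself. No step beyond the scatter is expected, with only a slight lean towards a higher number. The estimated change is a 1.4-fold higher number from compound 2 to compound 4 (0.14 log units; within the scatter). The expected value for compound 4 is 55 nM, with an estimated range from 20 nM to 140 nM.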

Compound 4, half-maximal inhibitory concentration: 420 nM
Estimate against measurement, compound 4: 7.6-fold (0.88 log units) below, and the stated range ends below it.
By their numbers in this assay, from the lowest: compound 2; then compounds 1, 4 and 3 (each within the scatter of the next, the first and the last beyond it).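

In this assay, among the compounds shown here, the group on this oxygen proves to be a sensitive point, which the earlier compounds could not show because no two of them differed in one place: isopropoxy to methoxy alone gives an 11-fold higher number from compound 2 to compound 4 (1.02 log units; beyond the scatter), a large step beyond the scatter. The exchange of 2-fluorophenyl for 5-(1-hydroxy-1-methylethyl)-2-methoxyphenyl gives a 1.8-fold higher number from compound 1 to compound 4 (0.26 log units; within the scatter), which is within the scatter, so with methoxy on the oxygen the larger aryl group is not distinguished from the 2-fluorophenyl group of compound 1. Nothing shown here accounts for the size of the isopropoxy to methoxy step.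

Only isopropyl and methyl are shown on this oxygen, so it remains open whether the number changes gradually with the group or whether isopropyl is a special case. An ethyl or cyclopropyl group there would help to settle this.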